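Methylamino in place of isopropoxy: expected solubility of compound 4

The compounds below may be only part of what the source reports. "The series", "measured", "known", "first", "only" and "open" are said of these compounds alone.

Compound 1, `CC(C)OCc1nc(Nc2ccc(C(F)(F)F)cc2)c2ccc(-c3ncccc3C(F)(F)F)cc2n1`: in a physicochemical assay for solubility, at pH 7.4 (on this read-out higher numbers stand for higher solubility and lower numbers for lower solubility), compound 1 gives 0.04 ug/mL.
Compound 2, `O=P(O)(O)OCc1nc(Nc2ccc(C(F)(F)F)cc2)c2ccc(-c3ncccc3C(F)(F)F)cc2n1`: for compound 2 this assay reports only a limit, > 138 ug/mL.
Compound 3, `CS(=O)(=O)CCc1nc(Nc2ccc(C(F)(F)F)cc2)c2ccc(-c3ncccc3C(F)(F)F)cc2n1`: in this assay compound 3 gives 0.2 ug/mL.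

Compound 1 stands lowest of the two numbers given. Its nearest neighbour is compound 3, and the step between them is modest: a 5.0-fold higher number from compound 1 to compound 3 (0.70 log units; beyond the scatter). The other measured step from compound 1 is large, an at least 3400-fold higher number from compound 1 to compound 2 (3.53 log units; beyond the scatter), and it ends at the limit of > 138 ug/mL in this assay, at which 1 of the 3 values shown sits, so its full size is not known.

Compound 4, `CNCc1nc(Nc2ccc(C(F)(F)F)cc2)c2ccc(-c3ncccc3C(F)(F)F)cc2n1`, is not yet measured. It differs from compound 1 at the same place where compounds 2 and 3 differ from it: methylamino in place of isopropoxy on a saturated chain carbon bound to an aromatic carbon.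

Both measured steps that start from compound 1 exchange the isopropoxy group and both run upward in this assay, one modestly and one by a large amount. A step upward beyond the scatter is therefore expected for compound 4 as well, estimated at a 500-fold higher number from compound 1 to compound 4 (2.70 log units; beyond the scatter). In this assay compound 4 is expected to give about 20 ug/mL, with a likely range from 2 ug/mL to 150 ug/mL.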

Compound 4, solubility: 10 ug/mL
Estimate against measurement, compound 4: 2.0-fold (0.30 log units) above, within the range that was stated.
By their numbers in this assay, from the lowest: compound 1; then compound 3; then compound 4. At a limit, above all of these: compound 2.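

In this assay, methylamino in place of isopropoxy gives a 250-fold higher number from compound 1 to compound 4 (2.40 log units; beyond the scatter), and the same place also gives a 50-fold higher number from compound 3 to compound 4 (1.70 log units; beyond the scatter). This shows that a large upward step at this saturated chain carbon does not need the phosphorus-bearing group of compound 2, as methylamino, with no phosphorus, also produces one. The remaining gap is an at least 13-fold lower number from compound 2 to compound 4 (1.13 log units; beyond the scatter), and its full size cannot be read, as the value of compound 2 is a limit: the limit of > 138 ug/mL in this assay, at which 1 of the 4 values shown sits.

The compounds shown leave open whether the step follows the nitrogen itself or the hydrogen-bond donor that enters with methylamino. On these data alone, how a dimethylamino group, a longer amine chain or a carboxylic acid would read at this place in this assay also stays open.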